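Aryl in place of alkyl on the ether chain

The source may report more compounds than this note shows. Statements on the series, on what has been measured and on what is new or still open speak of the compounds shown alone.

Within the data shown here, compound 2 `CCCCCCOc1ccc(C(O)C2OC(=O)c3c(OC)cc(OC)cc32)cc1` gives in a functional assay on RAW264.7 cells (Mus musculus) for inhibition, read by Griess assay, with stated times of 1 h and 24 h (a higher number here means a weaker inhibitor, a lower number a stronger inhibitor), 5360 nM, the only number in the set. Compound 1 `CCOc1ccc(C(O)C2OC(=O)c3c(OC)cc(OC)cc32)cc1` sits at the limit > 10000 nM in this assay. Compound 3 `COc1cc(OC)c2c(c1)C(C(O)c1ccc(OCCOc3ccccc3)cc1)OC2=O` sits at the limit > 10000 nM in this assay as well. One measured step, an at least 1.8-fold lower number from compound 1 to compound 2 (0.27 log units; that floor lies within the scatter), brought butyl in; the other, an at least 1.8-fold higher number from compound 2 to compound 3 (0.27 log units; that floor lies within the scatter), brought phenoxy in for butyl. Compound 4 `COc1cc(OC)c2c(c1)C(C(O)c1ccc(OCc3ccc(C)cc3)cc1)OC2=O` differs from compound 2 by 4-methylphenyl in place of pentyl on a saturated chain carbon bound to an oxygen on an aromatic ring. Both steps bear on it: the longer alkyl chain gave the lower number, the phenoxy the higher one, so the 4-methylphenyl of compound 4 points toward a higher number, perhaps the limit again. For compound 4 the expected step is a 1.7-fold higher number from compound 2 to compound 4 (0.23 log units; within the scatter). Compound 4 is estimated at 9000 nM, between 3500 nM and 20000 nM.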

Compound 4, half-maximal inhibitory concentration: 3120 nM
The estimate for compound 4 lay 2.9-fold (0.46 log units) above the measured number; measured number below the stated range.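

An aromatic ring on this ether chain holds up in this assay: a 1.7-fold lower number from compound 2 to compound 4 (0.24 log units; within the scatter), so 4-methylphenyl in place of pentyl leaves no readable change. Compound 4 also gives the first separations beyond the scatter in the set, with an at least 3.2-fold lower number from compound 3 to compound 4 (0.50 log units; beyond the scatter) and an at least 3.2-fold lower number from compound 1 to compound 4 (0.50 log units; beyond the scatter). Both are floors, as compound 1 and compound 3 stand at a limit rather than a number: the limit of > 10000 nM in this assay, at which 2 of the 4 values shown sit.

On these data alone, the role of the methyl group remains open, and a plain benzyl ether or a 4-methoxybenzyl ether would test it. As far as these compounds go, an amine or a carboxylic acid on the ether chain also remains open.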